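The compounds below may be only part of what the source reports. "The series", "measured", "known", "first", "only" and "open" are said of these compounds alone.

Compound 1 `COc1ccc2c(c1)OC(c1cc(OC)c(OC)c(OC)c1)C(CO)=C2` — in a functional assay for inhibition of nuclear factor NF-kappa-B complex (Homo sapiens) (a lower number here means a stronger inhibitor, a higher number a weaker inhibitor), compound 1 gives > 50000 nM, which is a limit of the assay rather than a number.
Compound 2 `COc1ccc2c(c1)OC(c1cc(OC)c(OC)c(OC)c1)C(C(=O)OC(C)C)=C2` — compound 2 gives 11800 nM.
Compound 3 `COc1ccc2c(c1)OC(c1cc(OC)c(OC)c(OC)c1)C=C2` — compound 3 gives 17700 nM.

Compound 3 holds the highest of the two numbers shown, with compound 2 nearest: a 1.5-fold higher number from compound 2 to compound 3 (0.18 log units; within the scatter). Compound 4 `COc1ccc2c(c1)OC(c1cc(OC)c(OC)c(OC)c1)C(C(=O)N(C)C)=C2` differs from compound 3 by dimethylcarbamoyl in place of hydrogen on a double-bonded ring carbon. Going by the values given here, the steps that bear on this change are an at least 4.2-fold lower number from compound 1 to compound 2 (0.62 log units; beyond the scatter) and an at least 2.8-fold lower number from compound 1 to compound 3 (0.45 log units; beyond the scatter), both starting from the limit of > 50000 nM in this assay, at which 1 of the 3 values shown sits, and a 1.5-fold higher number from compound 2 to compound 3 (0.18 log units; within the scatter), where another carbonyl-bearing group stands on a double-bonded ring carbon. Since the ester and the hydrogen gave numbers within the scatter of each other, compound 4 is expected to give about 14000 nM, between 5000 nM and 40000 nM. The estimated step of a 1.3-fold lower number from compound 3 to compound 4 (0.10 log units; within the scatter) is thus expected to stay within the scatter.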

Compound 4, half-maximal inhibitory concentration: > 50000 nM
Compound 4 ended at the assay's limit; the forecaster's own chance of this, stated with the estimate: 15%; at least 3.5-fold (0.55 log units) between middle value and limit.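

In this assay, carbonyl-bearing groups on this double-bonded ring carbon do not all behave alike: dimethylcarbamoyl gives an at least 2.8-fold higher number from compound 3 to compound 4 (0.45 log units; beyond the scatter), and the change on the carbonyl carbon from isopropoxy to dimethylamino gives an at least 4.2-fold higher number from compound 2 to compound 4 (0.62 log units; beyond the scatter). The earlier compounds shown here showed only that the ester and hydrogen lie within the scatter of each other, whereas the amide now marks a loss of inhibition. Compound 4 stands at a limit of the assay, not at a number: the limit of > 50000 nM in this assay, at which 2 of the 4 values shown sit.

The step from compound 1 to compound 4 cannot be read. Going by these compounds, it also remains open whether a carboxylic acid or an unsubstituted amide on this carbon would track the ester or the dimethylcarbamoyl group.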